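Replacing the aromatic amide group of compound 1

A few compounds are considered here, and "the series" means these few. Any claim that something is new, unique, unknown or untested is made for them only; others in the source may bear on it.

In a functional assay on MCF7 cells (Homo sapiens) for antiproliferative activity, read by MTT assay, with a stated time of 24 h (on this read-out lower numbers stand for stronger inhibition and higher numbers for weaker inhibition), compound 1 (`COC(=O)c1scc(-c2ccc(NC(=O)c3cccc(C(F)(F)F)c3)cc2)c1OC`) gives 26200 nM. Compound 2 (`COC(=O)c1scc(-c2ccc(NC(=O)c3ccc(C(F)(F)F)cc3Br)cc2)c1OC`) gives 22400 nM, within the scatter of compound 1, so the two share the high end of the three numbers measured. Compound 3 (`COC(=O)c1scc(-c2ccc(NC(=O)c3cccc(OC(F)(F)F)c3)cc2)c1OC`) gives 2220 nM, the furthest from compound 1.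

Going by the values given here, only one measured step changes a single place: a 12-fold lower number from compound 1 to compound 3 (1.07 log units; beyond the scatter). It is large and lies beyond the scatter, with trifluoromethoxy in place of trifluoromethyl on an aromatic carbon.

Compound 4 (`COC(=O)c1scc(-c2ccc(NC(=O)c3ccc(C#N)nc3)cc2)c1OC`) has not yet been measured. Its difference from compound 1 is 6-cyanopyridin-3-yl in place of 3-(trifluoromethyl)phenyl on a carbonyl carbon. This change removes the whole group, whereas the step to compound 3 altered only one substituent on it. That step, a 12-fold lower number from compound 1 to compound 3 (1.07 log units; beyond the scatter), therefore bears only loosely on compound 4. It shows that a change in this group can move the number widely, but it gives no firm direction here.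

The expected step in this assay is a 1.5-fold lower number from compound 1 to compound 4 (0.16 log units; within the scatter), an estimate that stays within the scatter. For compound 4 the estimated value is 18000 nM, with an expected range from 4000 nM to 60000 nM.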

Compound 4, half-maximal inhibitory concentration: 9540 nM
For compound 4 the middle estimate is 1.9-fold (0.28 log units) above the measured one; measured number inside the range.
By their numbers in this assay, from the lowest: compound 3; then compound 4; then compounds 2 and 1 (each within the scatter of the next).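

In this assay, a 2.7-fold lower number from compound 1 to compound 4 (0.44 log units; beyond the scatter) comes from exchanging the whole 3-(trifluoromethyl)phenyl group on the carbonyl carbon for 6-cyanopyridin-3-yl. The earlier single-place step, a 12-fold lower number from compound 1 to compound 3 (1.07 log units; beyond the scatter), changed only one substituent on the phenyl group, whereas this step shows that the number can also fall beyond the scatter when the carbon-only aromatic ring and all its fluorine leave together and a six-membered aromatic ring with a hetero atom and a nitrile enters. No measurement shown here accounts for the size or direction of this step.

The ring nitrogen and the nitrile enter in one step, so the share of each in the lower number stays unresolved. Still open, as far as these compounds go, is how the number would read with a plain pyridine ring lacking the nitrile, or with a carboxylic acid or an amine in place of the nitrile on the same ring.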